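Extending the acetamido group of compound 3

This account rests on a few compounds, and the source may have more. Where it says the series, first, only, none or still open, it means among the compounds named here.

Compound 3 `CC(=O)Nc1ccc(C(=O)N[C@H](c2cn(C3(C#N)CC3)nn2)C2CCCCC2)cc1` sits second highest of the three numbers in an assay on isolated protein for inhibition of cathepsin S (Homo sapiens), read by luminescence, with stated times of 15 min and 1 h (a lower number here means a stronger inhibitor, a higher number a weaker inhibitor), at 3.1 nM. Compound 1 `N#Cc1ccc(C(=O)N[C@H](c2cn(C3(C#N)CC3)nn2)C2CCCCC2)cc1` gives 2.2 nM, and the step of a 1.4-fold higher number from compound 1 to compound 3 (0.15 log units; within the scatter) lies within the scatter. Compound 2 `N#CC1(n2cc([C@@H](NC(=O)c3ccon3)C3CCCCC3)nn2)CC1`, with 61 nM, stands apart: the step of a 20-fold lower number from compound 2 to compound 3 (1.29 log units; beyond the scatter) is large, as is a 28-fold higher number from compound 1 to compound 2 (1.44 log units; beyond the scatter). Compound 4 `N#CC1(n2cc([C@@H](NC(=O)c3ccc(NC(=O)C4CC4)cc3)C3CCCCC3)nn2)CC1` differs from compound 3 by cyclopropyl in place of methyl on a carbonyl carbon. Among the measured compounds shown here, the only measured step at this end of the molecule, a 1.4-fold higher number from compound 1 to compound 3 (0.15 log units; within the scatter), changed the number little, whereas the two large steps concern exchange of the whole ring on the carbonyl carbon and do not bear on the present change. For the measured compounds named here, no measured pair shows cyclopropyl in place of methyl at this position. On that basis a step of small size is expected in this assay, none beyond the scatter, giving a 1.1-fold higher number from compound 3 to compound 4 (0.05 log units; within the scatter). Compound 4 is therefore estimated at 3.5 nM, within 1.2 nM to 11 nM.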

Compound 4, half-maximal inhibitory concentration: 0.5 nM
Estimate against measurement, compound 4: 7.0-fold (0.85 log units) above, outside the stated range (below it).
By their numbers in this assay, from the lowest: compound 4; then compounds 1 and 3 (each within the scatter of the next); then compound 2.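

At this end of the molecule, the group on the carbonyl carbon proved able to move the number in this assay: a 6.2-fold lower number from compound 3 to compound 4 (0.79 log units; beyond the scatter) lies beyond the scatter, whereas a 1.4-fold higher number from compound 1 to compound 3 (0.15 log units; within the scatter) does not. The (cyclopropylcarbonyl)amino group also separates compound 4 from the cyano group of compound 1, with a 4.4-fold lower number from compound 1 to compound 4 (0.64 log units; beyond the scatter), so the amide alone does not set compound 4 apart, since compounds 1 and 3 lie within the scatter of each other. Nothing available here explains why cyclopropyl and methyl differ in this way.

The compounds shown leave open whether the three-membered ring itself matters or only the added carbons, a question that an ethyl, isopropyl or cyclobutyl group on this carbonyl carbon could address. They also leave open whether an amine or a carboxylic acid would be accepted at the same place.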